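This account rests on a few compounds, and the source may have more. Where it says the series, first, only, none or still open, it means among the compounds named here.

Measured compounds in an assay on MCF7 cells for inhibition of Serine-protein kinase ATM (Homo sapiens), read by immunofluorescence, with a stated time of 1 h; on this read-out higher numbers stand for weaker inhibition and lower numbers for stronger inhibition:

Compound 1 `COc1cc2ncnc(-n3nc(-c4ccccn4)nc3N)c2cc1N` gives > 40000 nM, a limit of the assay.
Compound 2 `CCN(CC)C(=O)COc1cc2c(-n3nc(-c4ccccn4)nc3N)ncnc2cc1OC` gives 5300 nM.
Compound 3 `COc1cc2ncnc(-n3nc(-c4ccccn4)nc3N)c2cc1OCCCNC(=O)OC(C)(C)C` gives 900 nM.

Compound 3 holds the lowest of the two numbers in this assay; the nearest is compound 2, and the step is a 5.9-fold lower number from compound 2 to compound 3 (0.77 log units; beyond the scatter). Compound 1 sits at the limit of > 40000 nM in this assay, at which 1 of the 3 values shown sits. From it the steps are an at least 7.5-fold lower number from compound 1 to compound 2 (0.87 log units; beyond the scatter) and an at least 44-fold lower number from compound 1 to compound 3 (1.64 log units; beyond the scatter); both are read against a limit and give only their minimum size.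

Compound 4 `COc1cc2ncnc(-n3nc(-c4ccccn4)nc3N)c2cc1OCCCNC(=O)OCC(F)(F)F` differs from compound 3 by 2,2,2-trifluoroethyl in place of tert-butyl on an oxygen next to a carbonyl group. Within the data shown here, none of the measured steps touches this position: they exchange the whole group on the aromatic oxygen, or replace the amino group of compound 1, while the carbamate of compound 3 is kept intact. Among the measured compounds shown here, the step from compound 3 to compound 4 is therefore a change of a different kind than any measured one, and no measured step gives a direction for it. The expectation is a number for compound 4 in this assay near that of compound 3, with a step of a 1.2-fold higher number from compound 3 to compound 4 (0.09 log units; within the scatter) not expected to go beyond the scatter. The estimate for compound 4 is 1100 nM, within 350 nM to 3500 nM.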

Compound 4, half-maximal inhibitory concentration: 1200 nM
Compound 4: the middle estimate sits 1.1-fold (0.04 log units) below what was measured, and the stated range covers the measured number.
By their numbers in this assay, from the lowest: compounds 3 and 4 (each within the scatter of the next); then compound 2. At a limit, above all of these: compound 1.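

In this assay, among these compounds, 2,2,2-trifluoroethyl in place of tert-butyl on an oxygen next to a carbonyl group gives a 1.3-fold higher number from compound 3 to compound 4 (0.12 log units; within the scatter), the first reading at this end of the side chain, and the two carbamates cannot be told apart. Their different heavy-atom make-up, 4 carbon for tert-butyl against 2 carbon and 3 fluorine for 2,2,2-trifluoroethyl, therefore leaves no mark on this read-out. The new carbamate also stands apart from the diethylcarbamoyl compound, with a 4.4-fold lower number from compound 2 to compound 4 (0.65 log units; beyond the scatter), so the separation from compound 2 seen with the tert-butyl carbamate, a 5.9-fold lower number from compound 2 to compound 3 (0.77 log units; beyond the scatter), does not rest on tert-butyl alone, and nothing given here explains any of these steps.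

Still open, as far as these compounds go, is how much of the carbamate is needed at all, which a free primary amine, an acetamide or a urea at the end of the propoxy chain would test. Equally open, from the compounds shown here alone, is the chain itself, where a longer chain, or a carboxylic acid or morpholine at its end, would show whether the number in this assay moves beyond the scatter.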